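The source may report more compounds than this note shows. Statements on the series, on what has been measured and on what is new or still open speak of the compounds shown alone.

Series notes. Compound 2 `O=C(Nc1ccc(C(F)(F)F)cc1)NC1CCN(C(=O)c2ccoc2)CC1` serves as the point of reference; compound 1 `O=C(Nc1ccc(C(F)(F)F)cc1)NC1CCN(C(=O)C2CCCOC2)CC1` and compound 3 `O=C(Nc1ccc(OC(F)(F)F)cc1)NC1CCN(C(=O)c2ccoc2)CC1` each differ from it in one place, and compound 4 `O=C(Nc1ccc(OC(F)(F)F)cc1)NC1CCN(C(=O)C2CCCOC2)CC1` is the member still to be measured. In a physicochemical assay for lipophilicity, read by HPLC, with a stated time of 90 min, tested at 100 uM (a lower number here means a more polar compound, a higher number a more lipophilic compound), compound 2 gives 3.5, compound 1 gives 3.41 and compound 3 gives 3.63. The change oxan-3-yl in place of furan-3-yl on a carbonyl carbon produced a number 0.09 log units lower from compound 2 to compound 1 (within the scatter). The two cores differ by trifluoromethoxy in place of trifluoromethyl on an aromatic carbon, which produced a number 0.13 log units higher from compound 2 to compound 3 (within the scatter). From compound 3 to compound 4 the change is oxan-3-yl in place of furan-3-yl on a carbonyl carbon, the same change at the same place as the one already measured. The step from compound 3 to compound 4 in this assay is expected to be a number 0.09 log units lower from compound 3 to compound 4 (within the scatter). Among the measured compounds shown here, this expectation rests on compound 3 standing at 3.63 and on the single earlier instance, a number 0.09 log units lower from compound 2 to compound 1 (within the scatter). Compound 4 is therefore estimated at 3.54, with a range from 3.3 to 3.8.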

Compound 4, partition coefficient: 3.42
Estimate against measurement, compound 4: 0.12 log units above; the range from low to high includes it.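

In this assay the change to oxan-3-yl from furan-3-yl reads as a number 0.21 log units lower from compound 3 to compound 4 (within the scatter) on one core and as a number 0.09 log units lower from compound 2 to compound 1 (within the scatter) on the other, so on neither core does it leave a readable shift. With oxan-3-yl in place, trifluoromethoxy in place of trifluoromethyl reads as a number 0.01 log units higher from compound 1 to compound 4 (within the scatter). The two instances agree only in staying within the scatter, which does not show that the change carries a fixed size from core to core, and no supporting evidence bears on the result.

The compounds shown cover only two groups on the carbonyl carbon and two on the aromatic carbon. As far as these compounds go, whether an amine or a carboxylic acid on that carbonyl carbon would step beyond the scatter, and carry across both cores, remains open.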